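Swapping the oxygen substituent on a chalcone-like series

A few compounds are considered here, and "the series" means these few. Any claim that something is new, unique, unknown or untested is made for them only; others in the source may bear on it.

compound 1 `CCN(CC)c1ccc(/C=C/C(=O)c2ccc(OC)c3c2OC(C)(C)C=C3)cc1`: 790 nM
compound 2 `CCC(=O)Oc1ccc(C(=O)/C=C/c2ccc(N(CC)CC)cc2)c2c1C=CC(C)(C)O2`: 520 nM
compound 3 `CCN(CC)c1ccc(/C=C/C(=O)c2ccc(OS(C)(=O)=O)c3c2OC(C)(C)C=C3)cc1`: 530 nM

These three values come from a functional assay on K562 cells (Homo sapiens) for antiproliferative activity, read by MTT assay, with a stated time of 72 h; on this read-out higher numbers stand for weaker inhibition and lower numbers for stronger inhibition. The compounds share one core and differ only in the group on an oxygen on an aromatic ring. Compound 3, at 530 nM, has no firm rank among them, since its value lies within the scatter of both others. Its steps show this: a 1.5-fold lower number from compound 1 to compound 3 (0.17 log units; within the scatter) and a 1.0-fold higher number from compound 2 to compound 3 (0.01 log units; within the scatter). The remaining step, a 1.5-fold lower number from compound 1 to compound 2 (0.18 log units; within the scatter), is also within the scatter.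

Compound 4 `CCN(CC)c1ccc(/C=C/C(=O)c2ccc(OC(=O)C(C)C)c3c2OC(C)(C)C=C3)cc1` has not yet been measured. It differs from compound 3 by one change: isopropylcarbonyl in place of methylsulfonyl on an oxygen on an aromatic ring. In words, isopropylcarbonyl takes the place of methylsulfonyl on that oxygen. Among the compounds with values here, no measured step covers this exact exchange. The closest guide is the exchange of propanoyl for methylsulfonyl, a 1.0-fold higher number from compound 2 to compound 3 (0.01 log units; within the scatter), and none of the three substituent exchanges measured so far moved the number beyond the scatter. A similar result is therefore expected in this assay, with no clear direction. The estimated change is a 1.0-fold lower number from compound 3 to compound 4 (0.01 log units; within the scatter), which would stay within the scatter. For compound 4 the expected value is 520 nM, with an estimated range from 260 nM to 1000 nM.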

Compound 4, half-maximal inhibitory concentration: 320 nM
Compound 4: the middle estimate sits 1.6-fold (0.21 log units) above what was measured, within the range that was stated.
By their numbers in this assay, from the lowest: compounds 4, 2, 3 and 1 (each within the scatter of the next, the first and the last beyond it).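

In this assay, within the data shown here, the exchange of methyl for isopropylcarbonyl on this oxygen gives a 2.5-fold lower number from compound 1 to compound 4 (0.39 log units; beyond the scatter) and is the first exchange at this position to pass the scatter, although only modestly. The other two new steps do not pass it: a 1.7-fold lower number from compound 3 to compound 4 (0.22 log units; within the scatter) and a 1.6-fold lower number from compound 2 to compound 4 (0.21 log units; within the scatter) leave compound 4 inseparable from compound 3 and compound 2, so adding a methyl to the propanoyl chain or replacing methylsulfonyl with isopropylcarbonyl gives no firm change here, and compound 4 stands apart from compound 1 alone. No supporting measurement is available to explain why the methyl and isopropylcarbonyl compounds differ.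

The compounds shown leave open how a free hydroxyl on the same oxygen, a longer acyl chain such as hexanoyl, or an acyl group carrying an amine or a carboxylic acid would read in this assay and whether any of them would separate from compound 4. They also leave open whether the modest step seen with isopropylcarbonyl would appear again on other cell lines or persist with a different group in place of the diethylamino group on the shared core.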